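The source may report more compounds than this note shows. Statements on the series, on what has been measured and on what is new or still open speak of the compounds shown alone.

Compound 2 `Cc1cc(O)c(C2=NN(c3ccc(S(N)(=O)=O)cc3)C(c3ccccc3Cl)C2)cc1Cl` has been tested in a functional assay on NCI-H226 cells (Homo sapiens) for antiproliferative activity, with a stated time of 48 h (a lower number here means a stronger inhibitor of growth, a higher number a weaker inhibitor of growth), where compound 2 gives 9440 nM. For the measured compounds named here, of the two numbers measured so far this is the higher one, but its only neighbour, compound 1 `Cc1cc(O)c(C2=NN(c3ccc(S(N)(=O)=O)cc3)C(c3ccccc3O)C2)cc1Cl`, gives 7550 nM, and the step of a 1.3-fold higher number from compound 1 to compound 2 (0.10 log units; within the scatter) lies within the scatter, so the two compounds cannot be told apart in this assay. Compound 3 `COc1ccc(C2CC(c3cc(Cl)c(C)cc3O)=NN2c2ccc(S(N)(=O)=O)cc2)c(OC)c1OC` has not yet been measured. It differs from compound 2 in one place: 2,3,4-trimethoxyphenyl in place of 2-chlorophenyl on a saturated ring carbon. Going by the values given here, the single measured step, a 1.3-fold higher number from compound 1 to compound 2 (0.10 log units; within the scatter), altered a group on a different aromatic ring and stayed within the scatter; no measured step replaces the whole ring on this saturated ring carbon, so the data give little direct guidance. The expected step is therefore a 1.5-fold lower number from compound 2 to compound 3 (0.16 log units; within the scatter) in this assay, no change beyond the scatter, with a wide range. Compound 3 is estimated at 6500 nM, between 1500 nM and 28000 nM.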

Compound 3, concentration for total growth inhibition: 13300 nM
Compound 3: the middle estimate sits 2.0-fold (0.31 log units) below what was measured; measured number inside the range.
By their numbers in this assay, from the lowest: compounds 1, 2 and 3 (each within the scatter of the next).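

In this assay, the saturated ring carbon next to the ring nitrogen carries a far bigger group in compound 3 without a readable effect: the replacement of 2-chlorophenyl by 2,3,4-trimethoxyphenyl gives a 1.4-fold higher number from compound 2 to compound 3 (0.15 log units; within the scatter), and the replacement of 2-hydroxyphenyl by the same group gives a 1.8-fold higher number from compound 1 to compound 3 (0.25 log units; within the scatter). So a group of 12 heavy atoms with 3 hydrogen-bond acceptors cannot be told apart from either smaller group, and all three compounds lie within the scatter of one another. No other information here bears on this result.

Going by these compounds, what stays open is whether any group at this position can shift the number beyond the scatter. A phenyl ring bearing a carboxylic acid or an amine, or a cyclohexyl ring in place of the phenyl, would test this.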